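Swapping bromo for methylsulfanyl on compound 2

The compounds below may be only part of what the source reports. "The series", "measured", "known", "first", "only" and "open" are said of these compounds alone.

Values so far in a physicochemical assay for solubility, read by nephelometry, in phosphate buffer, measured as kinetic solubility, at pH 6.5; a higher number here means a more soluble compound, a lower number a less soluble compound
- Compound 1 `CCOC(=O)C1=C(O)/C(=C\c2cc(C)n(-c3ccc(F)cc3)c2C)N=C1C` gives 3.1 ug/mL
- Compound 2 `CCOC(=O)C1=C(C)N/C(=C/c2cc(C)n(-c3ccc(Br)cc3)c2C)C1=O` gives 2.1 ug/mL
- Compound 3 `CCOC(=O)C1=C(C)N/C(=C/c2cc(C)n(-c3cc(OC)c(OC)c(OO)c3)c2C)C1=O` gives 3.1 ug/mL

Compound 2 (2.1 ug/mL) sits within the usual scatter of repeated measurements of both compound 1 (3.1 ug/mL) and compound 3 (3.1 ug/mL), so these three numbers cannot be ranked.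

Compound 4 `CCOC(=O)C1=C(C)N/C(=C/c2cc(C)n(-c3ccc(SC)cc3)c2C)C1=O` is still unmeasured. It is compound 2 with methylsulfanyl in place of bromo on an aromatic carbon, para to a large group (methylsulfanyl in place of bromo on an aromatic carbon), so 4-bromophenyl becomes 4-(methylsulfanyl)phenyl. Among the compounds with values here, no pair of measured compounds shows this change or any other single change, so the data offer no direct guide to its size. Within the data shown here, the only anchor is compound 2 itself (2.1 ug/mL), whose number lies close to the other two. In this assay no step beyond the scatter is therefore expected, in either direction. The estimated step (a 1.2-fold higher number from compound 2 to compound 4 (0.08 log units; within the scatter)) stays within that scatter. The expected value for compound 4 is 2.5 ug/mL, with an estimated range from 1.1 ug/mL to 5.5 ug/mL as its bounds.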

Compound 4, solubility: 1.6 ug/mL
For compound 4 the middle estimate is 1.6-fold (0.19 log units) above the measured one; the measured number falls inside the stated range.
By their numbers in this assay, from the lowest: compounds 4, 2, 1 and 3 (each within the scatter of the next).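

Within the data shown here, this is the first pair here that differs in only one place, so the change from 4-bromophenyl to 4-(methylsulfanyl)phenyl can now be read directly in this assay: a 1.3-fold lower number from compound 2 to compound 4 (0.12 log units; within the scatter). On this aromatic carbon, para to a large group, the swap brings 2 heavy atoms in place of 1 and 1 hydrogen-bond acceptor in place of 0, yet compound 4 cannot be told apart from compound 2 in this read-out. No supporting measurement offers an explanation for this result.

A single swap leaves open whether a different group at this position, such as an amine or a carboxylic acid, would give a step beyond the scatter. Going by these compounds, whether a longer chain on the sulfur would do so also remains open.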